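Difluorophenyl replacing aminophenyl on the enone core

The source may report more compounds than this note shows. Statements on the series, on what has been measured and on what is new or still open speak of the compounds shown alone.

Three compounds of the series have been run in a functional assay on NCI-H322M cells (Homo sapiens) for cytotoxicity, read by sulforhodamine B assay, with a stated time of 48 h, tested at 1 uM; a higher number here means a weaker effect of the compound at the concentration tested, a lower number a stronger effect. Compound 1 `COc1cc(-c2cc(/C=C/C(=O)c3ccc(N)cc3)[nH]n2)cc(OC)c1OC` gives 94%; compound 2 `COc1ccc(-c2cc(/C=C/C(=O)c3cc(OC)c(OC)c(OC)c3)[nH]n2)cc1OC` gives 82%; compound 3 `COc1cc(C(=O)/C=C/c2cc(-c3cc(OC)c(OC)c(OC)c3)n[nH]2)cc(OC)c1OC` gives 89%. Of the three numbers that of compound 1 is the highest; compound 3 lies within the scatter of it, compound 2 beyond it. For the measured compounds named here, the one step between compounds that differ in a single place, a number 7 percentage points higher from compound 2 to compound 3 (within the scatter), concerns a methoxy on an aromatic carbon and stays within the scatter.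

Compound 4 `COc1cc(-c2cc(/C=C/C(=O)c3ccc(F)c(F)c3)[nH]n2)cc(OC)c1OC` differs from compound 1 by 3,4-difluorophenyl in place of 4-aminophenyl on a carbonyl carbon. Going by the values given here, no measured step touches the aryl group on the carbonyl carbon, so there is nothing that speaks for a shift in either direction, and the one step that is known is itself within the scatter. The step of a number 4 percentage points lower from compound 1 to compound 4 (within the scatter) is therefore expected to stay within the scatter. For compound 4 in this assay an estimate of 90% is made, with a range from 74% to 102%.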

Compound 4, a percentage reported as activity, at one concentration (the size of the read-out at that concentration, not a potency): 86%
Compound 4: the middle estimate sits 4 percentage points above what was measured, within the range that was stated.
By their numbers in this assay, from the lowest: compounds 2, 4, 3 and 1 (each within the scatter of the next, the first and the last beyond it).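

In this assay, for the compounds shown here, the aryl group on the carbonyl carbon is varied for the first time, and the result is a number 8 percentage points lower from compound 1 to compound 4 (within the scatter). At this place, then, 3,4-difluorophenyl, with 0 hydrogen-bond donors and 0 hydrogen-bond acceptors, cannot be told apart from 4-aminophenyl, with 1 of each, at the single concentration tested. Nothing at hand bears on why these two groups read alike.

As far as these compounds go, it remains open whether a quite different group on the carbonyl carbon, such as a carboxylic acid-bearing phenyl or a simple pyridine ring, would move the read-out beyond the scatter. From the compounds shown here alone, it is also open whether 3,4-difluorophenyl would read the same way on the core of compound 2.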